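The source may report more compounds than this note shows. Statements on the series, on what has been measured and on what is new or still open speak of the compounds shown alone.

Two measured compounds set the scene. In a physicochemical assay for pharmacokinetics (on this read-out higher numbers stand for a longer-lived compound and lower numbers for a shorter-lived compound), compound 1 (`O=C(NCc1ccccc1F)N1C(=O)c2ccccc2S1(=O)=O`) gives 0.598 h and compound 2 (`O=C(NCc1cccc(Br)c1)N1C(=O)c2ccccc2S1(=O)=O`) gives 0.492 h as its reading. Compound 2 therefore stands within the scatter of compound 1, and the two cannot be told apart. Compound 3 (`O=C(NCc1ccccc1Cl)N1C(=O)c2ccccc2S1(=O)=O`) differs from compound 2 in one place, with 2-chlorophenyl in place of 3-bromophenyl on a saturated chain carbon bound to an amide-type nitrogen. Going by the values given here, the one measured step at that place is a 1.2-fold lower number from compound 1 to compound 2 (0.08 log units; within the scatter) and it is the only guide available. A step beyond the scatter is therefore not expected in this assay, in either direction. The expected step is a 1.1-fold higher number from compound 2 to compound 3 (0.05 log units; within the scatter) by this estimate. For compound 3 the estimated value is 0.55 h with an expected range from 0.33 h to 0.9 h in this measurement.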

Compound 3, half-life: 0.42 h
The estimate for compound 3 lay 1.3-fold (0.12 log units) above the measured number; the range from low to high includes it.
By their numbers in this assay, from the lowest: compounds 3, 2 and 1 (each within the scatter of the next).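

Going by these compounds alone, compound 3 supplies the first pair in which the halogen changes while the ring place stays the same: chloro in place of fluoro on an aromatic carbon gives a 1.4-fold lower number from compound 1 to compound 3 (0.15 log units; within the scatter) in this assay and stays within the scatter. The change from 3-bromophenyl to 2-chlorophenyl gives a 1.2-fold lower number from compound 2 to compound 3 (0.07 log units; within the scatter) and is also within the scatter. All three halogen-bearing phenyl groups on the saturated chain carbon bound to an amide-type nitrogen therefore remain indistinguishable on this read-out, whether the change is to the halogen alone or to both the halogen and its ring place.

As far as these compounds go, whether this tolerance extends beyond halogens, to a phenyl group carrying an amine or a carboxylic acid, or to a longer chain at this place, remains open. Nothing available explains these readings.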